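The source may hold more compounds than are shown below. What is called first, only, known or untested is meant among the compounds shown, and "the series" means these compounds.

In a functional assay on a cell-free system (plasma, Oryctolagus cuniculus) for inhibition, with stated times of 5 min, 1 min and 6 min (a higher number here means a weaker inhibitor, a lower number a stronger inhibitor), compound 1 `CCOC(=O)c1c(C)nc(-c2cccc(C#N)c2)n1OCc1cccc(F)c1` gives 22400 nM, while compound 2 `CCOC(=O)c1c(C)nc(-c2cccc(C#N)c2)n1OCc1ccc(OC)cc1` gives 6830 nM, the lower of the two numbers. Compound 3 `CCOC(=O)c1c(C)nc(-c2cccc(C#N)c2)n1OCc1ccc([N+](=O)[O-])cc1` has nitro in place of methoxy on an aromatic carbon, para to a large group: nitro in place of methoxy on an aromatic carbon. For the measured compounds named here, the one measured step bearing on this is a 3.3-fold lower number from compound 1 to compound 2 (0.52 log units; beyond the scatter), which came with 4-methoxyphenyl in place of 3-fluorophenyl. With that 4-methoxyphenyl now given up, a modest step towards a higher number is expected in this assay. The estimated change is a 1.8-fold higher number from compound 2 to compound 3 (0.24 log units; within the scatter). Compound 3 is expected at 12000 nM, with an estimated range of 3500 nM to 35000 nM.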

Compound 3, half-maximal inhibitory concentration: 8750 nM
The estimate for compound 3 lay 1.4-fold (0.14 log units) above the measured number; measured number inside the range.
By their numbers in this assay, from the lowest: compounds 2 and 3 (each within the scatter of the next); then compound 1.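

In this assay, nitro in place of methoxy on this aromatic carbon, para to a large group, cannot be told apart from methoxy: the change gives a 1.3-fold higher number from compound 2 to compound 3 (0.11 log units; within the scatter) and stays within the scatter. The 4-nitrophenyl compound also stands clear of the 3-fluorophenyl one, with a 2.6-fold lower number from compound 1 to compound 3 (0.41 log units; beyond the scatter) beyond the scatter, so the lower number seen with 4-methoxyphenyl does not require methoxy itself. No measurement at hand accounts for this. Going by these compounds, it remains open whether an amine or a carboxylic acid on the same aromatic carbon would hold this level.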